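Hexyl hydrazide series: acetamidomethyl on the benzyl ring

This account rests on a few compounds, and the source may have more. Where it says the series, first, only, none or still open, it means among the compounds named here.

Of the compounds shown here, two on the shared core have numbers so far. Compound 1 `CCCNNC(=O)c1cnc(NCc2ccccc2)nc1` gives in an assay on isolated protein for inhibition of histone deacetylase 8 (Homo sapiens), read by fluorescence, with a stated time of 5 min (a lower number here means a stronger inhibitor, a higher number a weaker inhibitor), a value of 1000 nM. Compound 2 `CCCCCCNNC(=O)c1cnc(NCc2ccccc2)nc1` gives in this assay a value of 16 nM. Going by the values given here, the one measured step, a 63-fold lower number from compound 1 to compound 2 (1.80 log units; beyond the scatter), concerns only the chain on the hydrazide nitrogen. Among the compounds with values here, compound 2 stands lowest of the two numbers; the only other number, that of compound 1, lies beyond the scatter above it, as that step shows.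

Compound 3 `CCCCCCNNC(=O)c1cnc(NCc2ccc(CNC(C)=O)cc2)nc1` differs from compound 2 by acetamidomethyl in place of hydrogen on an aromatic carbon. Within the data shown here, no measured step touches the benzyl ring: the step from compound 1 to compound 2 changes a different part of the molecule and gives no guidance on substitution there. The measured record thus offers nothing to support a shift in either direction in this assay for this change, and the expectation is for no step beyond the scatter, with a wide margin on both sides.

On that basis compound 3 is estimated at 20 nM, with a range from 5 nM to 80 nM, which corresponds to an expected step of a 1.3-fold higher number from compound 2 to compound 3 (0.10 log units; within the scatter).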

Compound 3, half-maximal inhibitory concentration: 19 nM
Beside the measured number, compound 3's estimate is 1.1-fold (0.02 log units) above it, and the stated range covers the measured number.
By their numbers in this assay, from the lowest: compounds 2 and 3 (each within the scatter of the next); then compound 1.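

With the hexyl chain fixed on the hydrazide nitrogen, the benzyl ring now has its first measured substitution: in this assay, acetamidomethyl in place of hydrogen on an aromatic carbon, para to a large group, gives a 1.2-fold higher number from compound 2 to compound 3 (0.07 log units; within the scatter) and stays in the same low range of numbers as the parent. This position therefore accepts an entering group of 5 heavy atoms, with 1 hydrogen-bond donor and 1 hydrogen-bond acceptor, without a step beyond the scatter, so the ring offers a point of substitution that the chain step from compound 1 to compound 2 could not reveal. No measurement in hand accounts for the absence of a larger step at this position.

Still open, on these data alone, is whether a primary amine or a carboxylic acid at this same place would also stay within the scatter of compound 2, or whether the amide of compound 3 is one acceptable case among few. Also open, as far as these compounds go, is how acetamidomethyl behaves on other carbons of the ring, and whether a longer chain than hexyl on the hydrazide nitrogen would combine with it.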